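The compounds below may be only part of what the source reports. "The series", "measured", "known", "first", "only" and "open" are said of these compounds alone.

Working notes on the series. For the measured compounds named here, the two measured members share one core: compound 1 `COc1cc(N(C)C)c(NC(=O)c2ccncc2)cc1Nc1nccc(-c2cn(C)c3ccccc23)n1` and compound 2 `COc1cc(N(C)C)c(NC(=O)c2ccnc(Cl)c2)cc1Nc1nccc(-c2cn(C)c3ccccc23)n1`. In a functional assay on A549 cells (Homo sapiens) for antiproliferative activity, read by MTT assay, with a stated time of 72 h (a lower number here means a stronger inhibitor, a higher number a weaker inhibitor), compound 1 gives 9000 nM, and in this assay compound 2 gives 3430 nM. Going by the values given here, the only measured step, a 2.6-fold lower number from compound 1 to compound 2 (0.42 log units; beyond the scatter), places compound 2 at the lowest of the two numbers so far.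

Compound 3 `COc1cc(N(C)C)c(NC(=O)c2ccncc2OC)cc1Nc1nccc(-c2cn(C)c3ccccc23)n1` differs from compound 2 in one place: 3-methoxypyridin-4-yl in place of 2-chloropyridin-4-yl on a carbonyl carbon. Among the compounds with values here, no measured pair carries a methoxy on this ring, so no step bears directly on the change. The step of a 2.6-fold lower number from compound 1 to compound 2 (0.42 log units; beyond the scatter) shows only that a substituent on this ring can move the number by a modest amount; it says nothing about the direction for a methoxy group. A step of a 1.5-fold higher number from compound 2 to compound 3 (0.16 log units; within the scatter) of no more than the scatter is therefore expected, with a wide range. Compound 3 is estimated at 5000 nM, between 1500 nM and 16000 nM.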

Compound 3, half-maximal inhibitory concentration: 3030 nM
Compound 3: the middle estimate sits 1.7-fold (0.22 log units) above what was measured; measured number inside the range.
By their numbers in this assay, from the lowest: compounds 3 and 2 (each within the scatter of the next); then compound 1.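

In this assay, adding the methoxy group gives a 3.0-fold lower number from compound 1 to compound 3 (0.47 log units; beyond the scatter), so a step beyond the scatter on this ring is not confined to chloro. Exchanging 2-chloropyridin-4-yl for 3-methoxypyridin-4-yl on the carbonyl carbon gives a 1.1-fold lower number from compound 2 to compound 3 (0.05 log units; within the scatter), which lies within the scatter, so this assay does not separate the two groups. No evidence is available to explain either step.

The compounds shown do not separate the effect of the group from that of its location, as chloro and methoxy each appear only as they stand in 2-chloropyridin-4-yl and 3-methoxypyridin-4-yl. From the compounds shown here alone, it also remains open whether an amine or a carboxylic acid on this ring would move the number further, or leave it within the scatter of these values.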